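The source may report more compounds than this note shows. Statements on the series, on what has been measured and on what is new or still open speak of the compounds shown alone.

Compound 1 `COc1cccc(/C=C2\CCC/C(=C\c3ccccc3Cl)C2=O)c1OC`: 44200 nM
Compound 2 `COc1cccc(/C=C2\CCC/C(=C\c3ccccc3Br)C2=O)c1OC`: > 50000 nM

In an ADME assay on NHDF cells (Homo sapiens) for cytotoxicity, read by MTT assay, with a stated time of 72 h (a higher number here means a weaker inhibitor, a lower number a stronger inhibitor), compound 1 gives 44200 nM. Compound 2 reaches only a limit of the assay, > 50000 nM, and not a number. This is the limit of > 50000 nM in this assay, at which 1 of the 2 values shown sits.

Compound 3 `COc1cccc(/C=C2\CCC/C(=C\c3ccc(Br)cc3)C2=O)c1OC` has 4-bromophenyl in place of 2-bromophenyl on a double-bonded chain carbon bound to a double-bonded ring carbon. For the measured compounds named here, the only measured step, an at least 1.1-fold higher number from compound 1 to compound 2 (0.05 log units; that floor lies within the scatter), exchanges chloro for bromo and does not shift the group, so it bears only loosely on this change. No step beyond the scatter is therefore expected in this assay. The expected step is an at least 1.0-fold lower number from compound 2 to compound 3 (0.01 log units; that floor lies within the scatter). For compound 3 the estimated value is 48000 nM, with an expected range of 22000 nM to 85000 nM.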

Compound 3, half-maximal inhibitory concentration: 21400 nM
For compound 3 the middle estimate is 2.2-fold (0.35 log units) above the measured one; measured number outside the range, below it.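

In this assay, 4-bromophenyl in place of 2-bromophenyl gives the first step shown to lie beyond the scatter, an at least 2.3-fold lower number from compound 2 to compound 3 (0.36 log units; beyond the scatter), so the place of the bromine matters here in a way the exchange of chloro for bromo did not show. The comparison with 2-chlorophenyl points the same way, a 2.1-fold lower number from compound 1 to compound 3 (0.32 log units; beyond the scatter), though that step changes halogen and place together. The first step is only a floor, since compound 2 stands at a limit of the assay and not at a number: the limit of > 50000 nM in this assay, at which 1 of the 3 values shown sits.

The compounds shown leave open whether 3-bromophenyl or 4-chlorophenyl would follow 4-bromophenyl. They also leave open how an amine or a carboxylic acid in that place would read.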